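The source may report more compounds than this note shows. Statements on the series, on what has been measured and on what is new or still open speak of the compounds shown alone.

Measured so far in an assay on RBL-1 cells for inhibition of Polyunsaturated fatty acid 5-lipoxygenase (Rattus norvegicus); on this read-out lower numbers stand for stronger inhibition and higher numbers for weaker inhibition:
Compound 1 `O=C1NCCN(c2ccccn2)N1` gives 26000 nM.
Compound 2 `O=C1NCCN(c2cccc(Cl)n2)N1` gives 5600 nM.
Compound 3 `CC1CN(c2cccc(Cl)n2)NC(=O)N1` gives 3500 nM.

Compound 2 stands second highest of the three numbers: compound 3 lies within the scatter of it, the step being a 1.6-fold lower number from compound 2 to compound 3 (0.20 log units; within the scatter), while compound 1 sits clearly higher, the step being a 4.6-fold lower number from compound 1 to compound 2 (0.67 log units; beyond the scatter). Compound 4 `O=C1NCCN(c2cccc(Br)n2)N1` differs from compound 2 by bromo in place of chloro on an aromatic carbon. Going by the values given here, no measured step exchanges one halogen for another; the only step touching this aromatic carbon is a 4.6-fold lower number from compound 1 to compound 2 (0.67 log units; beyond the scatter), chloro in place of hydrogen. For bromo in place of chloro no step beyond the scatter is expected in this assay, with a small gain possible. Compound 4 is therefore estimated at 4500 nM, range 2000 nM to 11000 nM. The expected step is a 1.2-fold lower number from compound 2 to compound 4 (0.09 log units; within the scatter).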

Compound 4, half-maximal inhibitory concentration: 3500 nM
Compound 4: the middle estimate sits 1.3-fold (0.11 log units) above what was measured, within the range that was stated.
By their numbers in this assay, from the lowest: compounds 3, 4 and 2 (each within the scatter of the next); then compound 1.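

In this assay, the halogen on this aromatic carbon next to the ring nitrogen can be exchanged without a step beyond the scatter: bromo in place of chloro gives a 1.6-fold lower number from compound 2 to compound 4 (0.20 log units; within the scatter). Bromo in place of hydrogen gives a 7.4-fold lower number from compound 1 to compound 4 (0.87 log units; beyond the scatter), so the drop seen with chloro is shared by both halogens in compound 2 and compound 4. Nothing available explains these steps.

As far as these compounds go, whether an amine, a methoxy group or a carboxylic acid on this carbon would hold that drop remains open. Also open, from the compounds shown here alone, is how bromo behaves together with the ring methyl of compound 3.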